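Fluoro added to the aryl amide of compound 3

The source may report more compounds than this note shows. Statements on the series, on what has been measured and on what is new or still open speak of the compounds shown alone.

Notes on three measured compounds and one open step in an assay on SK-OV-3 cells for inhibition of Indoleamine 2,3-dioxygenase 1 (Homo sapiens); on this read-out higher numbers stand for weaker inhibition and lower numbers for stronger inhibition. Compound 1 `O=C(/C(=N/O)Nc1ccc(F)c(Cl)c1)N1CCC(c2ccccc2)CC1` gives 14000 nM. Compound 2 `O=C(Nc1ccc(Cl)cc1)C(=O)N1CCC(c2ccccc2)CC1` gives 90 nM. Compound 3 `O=C(Nc1ccc(Cl)cc1)C(=O)N1CCC(c2ccnc3ccc(F)cc23)CC1` gives 15 nM. Compound 3 therefore carries the lowest number of the three; the gap to compound 2 is beyond the scatter, and the gap to compound 1 is far beyond it. No pair of these compounds differs in a single place, so no step is available to calibrate the next change.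

Compound 4 `O=C(Nc1ccc(Cl)cc1F)C(=O)N1CCC(c2ccnc3ccc(F)cc23)CC1` is the unmeasured candidate. Its difference from compound 3 is fluoro in place of hydrogen on an aromatic carbon. Nothing measured here bears on a change of this kind, so the expectation rests on compound 3 alone. The step from compound 3 to compound 4 is expected to be small, a 1.3-fold lower number from compound 3 to compound 4 (0.10 log units; within the scatter), most likely none beyond the scatter, with a slight lean toward a lower number. Compound 4 is estimated at 12 nM, with a range from 4 nM to 40 nM.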

Compound 4, half-maximal inhibitory concentration: 7 nM
Beside the measured number, compound 4's estimate is 1.7-fold (0.23 log units) above it, and the stated range covers the measured number.
By their numbers in this assay, from the lowest: compound 4; then compound 3; then compound 2; then compound 1.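

In this assay, among the compounds shown here, the change from 4-chlorophenyl to 4-chloro-2-fluorophenyl provides the first step that differs in one place only, a 2.1-fold lower number from compound 3 to compound 4 (0.33 log units; beyond the scatter), a modest change. The aromatic carbon ortho to a large group and meta to the chloro group therefore accepts fluoro without any loss, and the number moves lower. The result also shows that a single added heavy atom on the aryl amide can shift this read-out when the rest of compound 3 stays unchanged.

On these data alone, it remains open whether a methyl or methoxy group on the same carbon would go the same way, and whether fluoro gives a similar step on the core of compound 2. Nothing shown here accounts for the size or direction of the step.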